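Aryl swap on the aromatic nitrogen of compound 3

The source may report more compounds than this note shows. Statements on the series, on what has been measured and on what is new or still open speak of the compounds shown alone.

Compound 1 `CNC(=O)c1cc(Oc2ccc(NC(=O)c3nn(-c4ccc(Br)cc4F)c(=O)cc3C)cc2F)ccn1`: 2830 nM
Compound 2 `Cc1ccc(-n2nc(C(=O)Nc3ccc(Oc4ncnc5ccsc45)cc3)c(C)cc2=O)cc1`: 25000 nM
Compound 3 `Cc1cc(=O)n(-c2ccc(Br)cc2F)nc1C(=O)Nc1ccc(Oc2ncnc3ccsc23)c(F)c1`: 3350 nM

In a functional assay on HepG2 cells (Homo sapiens) for cytotoxicity, read by MTT assay, with a stated time of 72 h (on this read-out higher numbers stand for weaker inhibition and lower numbers for stronger inhibition), compound 3 gives 3350 nM, the second highest of the three numbers; its nearest neighbour is compound 1, while compound 2 sits furthest away. Compound 4 `Cc1ccc(-n2nc(C(=O)Nc3ccc(Oc4ncnc5ccsc45)c(F)c3)c(C)cc2=O)cc1` differs from compound 3 by 4-methylphenyl in place of 4-bromo-2-fluorophenyl on an aromatic nitrogen. For the measured compounds named here, the only measured step, a 1.2-fold higher number from compound 1 to compound 3 (0.07 log units; within the scatter), concerns a different position and says nothing about this aryl swap. Compound 2, which carries the same 4-methylphenyl group but lacks the fluorine on the anilide ring, gives 25000 nM in this assay, a weaker number than compound 3. A step of a 4.5-fold higher number from compound 3 to compound 4 (0.65 log units; beyond the scatter) toward weaker inhibition is therefore expected. Compound 4 is estimated at 15000 nM, ranging from 5000 nM to 45000 nM.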

Compound 4, half-maximal inhibitory concentration: 17300 nM
Compound 4: middle estimate off by 1.2-fold (0.06 log units), on the low side, within the range that was stated.
By their numbers in this assay, from the lowest: compounds 1 and 3 (each within the scatter of the next); then compounds 4 and 2 (each within the scatter of the next).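

In this assay, for the compounds shown here, the exchange of 4-bromo-2-fluorophenyl for 4-methylphenyl on the aromatic nitrogen gives a 5.2-fold higher number from compound 3 to compound 4 (0.71 log units; beyond the scatter) as the first measured step at this position, toward weaker inhibition. With 4-methylphenyl held in place, fluoro in place of hydrogen on an aromatic carbon gives a 1.4-fold lower number from compound 2 to compound 4 (0.16 log units; within the scatter) and does not separate the two compounds. No measurement here explains the aryl step.

The swap changes bromine, fluorine and methyl together, and the compounds shown do not tell which of these carries the step. From the compounds shown here alone, how a phenyl bearing bromo alone or an aminophenyl on this nitrogen would read remains open.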